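Trimming a linker: from compound 1 to compound 3

The compounds below may be only part of what the source reports. "The series", "measured", "known", "first", "only" and "open" are said of these compounds alone.

Measured so far:
compound 1 `Cc1c(OCCCCOCOc2ccc(C(=O)O)cc2)ccc(C(=O)CC2CCCC2)c1O` with 95.4%
compound 2 `CCC(=O)c1ccc(OCCCCOc2cc(C(=O)O)ccc2OC)c(C)c1O` with 72.6%

In an assay on HEK293 cells for positive allosteric modulation of metabotropic glutamate receptor 2 (Rattus norvegicus), read by thallium flux, with a stated time of 2.5 min (a lower number here means a smaller maximal response, a higher number a larger maximal response), compound 1 gives the higher of the two numbers; compound 2 gives 72.6%, a number lower by more than the usual scatter. Compound 3 `Cc1ccc(C(=O)O)cc1OCCCCOc1ccc(C(=O)CC2CCCC2)c(O)c1C` has not been measured yet. It differs from compound 1 in one place: 5-carboxy-2-methylphenyl in place of (4-carboxyphenoxy)methyl on an oxygen on a saturated carbon. The acid-bearing ring thus sits closer to the rest of the molecule, as it also does in compound 2. Among the measured compounds shown here, no step between measured compounds is available, so the direction is uncertain. A modest step downward is expected, a number 10.4 percentage points lower from compound 1 to compound 3 (beyond the scatter), drawn partly by compound 2 and its 72.6%, while the shared core with compound 1 argues for staying near its 95.4%. Compound 3 is expected to reach about 85%, within 68% to 100%.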

Compound 3, largest response reached (reported as percent of maximum), in percent of the reference or control that the assay uses: 67.5%
For compound 3 the middle estimate is 17.5 percentage points above the measured one, and the stated range ends above it.
By their numbers in this assay, from the lowest: compounds 3 and 2 (each within the scatter of the next); then compound 1.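

Among the compounds shown here, this is the first step measured at this place, on an oxygen on a saturated carbon. In this assay, putting 5-carboxy-2-methylphenyl in place of (4-carboxyphenoxy)methyl gives a number 27.9 percentage points lower from compound 1 to compound 3 (beyond the scatter) and so shows that the maximal response depends on the group held here, even though both groups carry a carboxylic acid on one six-membered aromatic ring of carbon only and the rest of the molecule stays the same. No measurement accompanies this result that could explain the fall.

The change alters the ring's attachment, an oxygen and a methyl at once, which leaves open which of these parts accounts for the step. Also open, on these data alone, is how a chloro or methoxy group in place of that methyl would read in this assay.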